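Swapping Methoxy for Fluoro on a Triazole Side Arm

This account rests on a few compounds, and the source may have more. Where it says the series, first, only, none or still open, it means among the compounds named here.

Of the compounds shown here, three built on a shared core have been tested in a functional assay on HL-60 cells (Homo sapiens) for cytotoxicity, read by MTT assay, with a stated time of 4 days; a higher number here means a weaker inhibitor, a lower number a stronger inhibitor. Compound 1 `C=C1C[C@]23C[C@@]1(O)CC[C@H]2c1ccc(OS(=O)(=O)c2ccc(C)cc2)c(C)c1[C@@H]3Cn1cc(-c2ccc(OC)cc2)nn1` reaches only the limit of the assay, > 20000 nM, which is a boundary rather than a number. Compound 3 `C=C1C[C@]23C[C@@]1(O)CC[C@H]2c1cc(Br)c(O)c(C)c1[C@@H]3Cn1cc(-c2ccc(C)cc2)nn1` likewise stops at a limit, > 20000 nM. Compound 2 `COc1ccc(-c2cn(C[C@H]3c4c(ccc(O)c4C)[C@@H]4CC[C@@]5(C)C[C@]43CC5=O)nn2)cc1`, the starting point of the step followed here, also returns only a limit in this assay, > 20000 nM. Among the measured compounds shown here, compound 2 therefore stands exactly where every value so far stands: the limit of > 20000 nM in this assay, at which 3 of the 3 values shown sit. For the measured compounds named here, no compound has yet given a measured number that could serve as a reference point.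

Compound 4 `Cc1c(O)ccc2c1[C@H](Cn1cc(-c3ccc(F)cc3)nn1)[C@@]13CC(=O)[C@@](C)(CC[C@@H]21)C3` has not yet been measured in this assay. It differs from compound 2 in one place: fluoro in place of methoxy on an aromatic carbon. The fluoro sits on an aromatic carbon of a six-membered aromatic ring of carbon only, para to a large group, where the methoxy of compound 2 had been.

Going by the values given here, no step between two measured compounds exists to guide the size of this change. Because all three values shown sit at the limit of > 20000 nM in this assay, at which 3 of the 3 values shown sit, the step from compound 2 to compound 4 is expected to be a step that the limit leaves unreadable from compound 2 to compound 4, no movement beyond the scatter. Compound 4 is therefore estimated at 25000 nM in this assay, within 8000 nM to 80000 nM, and most likely once again reported only as a limit.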

Compound 4, half-maximal inhibitory concentration: > 20000 nM
Compound 4: a limit, no number (the forecaster's own chance of this, stated with the estimate: 80%); the middle value is on the limit's open side.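

Compound 2 and compound 4 both stop at a limit rather than a number, so the swap of methoxy for fluoro gives no step that can be read in this assay: the limit of > 20000 nM in this assay, at which 4 of the 4 values shown sit.

The compounds shown leave open how methoxy and fluoro compare, and whether any compound on this shared core gives a measured number in this assay.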